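The source may report more compounds than this note shows. Statements on the series, on what has been measured and on what is new or still open speak of the compounds shown alone.

Measured so far in a functional assay on MT4 cells (Homo sapiens); on this read-out higher numbers stand for lower toxicity in this test and lower numbers for higher toxicity in this test:
compound 1, `Cc1cn([C@@H]2O[C@H](CO[Si](C)(C)C(C)(C)C)[C@@]3(OS(=O)(=O)C=C3NC(N)=O)[C@H]2O[Si](C)(C)C(C)(C)C)c(=O)n(C)c1=O`: 3700 nM
compound 2, `COC(=O)NC1=CS(=O)(=O)O[C@@]12[C@@H](CO[Si](C)(C)C(C)(C)C)O[C@@H](n1cc(C)c(=O)n(C)c1=O)[C@@H]2O[Si](C)(C)C(C)(C)C`: 29900 nM
compound 3, `Cc1cn([C@@H]2O[C@H](CO[Si](C)(C)C(C)(C)C)[C@@]3(OS(=O)(=O)C=C3NCCC(N)=O)[C@H]2O[Si](C)(C)C(C)(C)C)c(=O)n(C)c1=O`: 20000 nM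

Compound 1 gives the lowest number of the three. Going from compound 1 to compound 2 the change is methoxy in place of amino on a carbonyl carbon, and it made an 8.1-fold higher number from compound 1 to compound 2 (0.91 log units; beyond the scatter). Compound 3 differs from compound 1 by 2-carbamoylethyl in place of carbamoyl on an amine nitrogen, a change that made a 5.4-fold higher number from compound 1 to compound 3 (0.73 log units; beyond the scatter). Between compound 2 and compound 3 the step is a 1.5-fold lower number from compound 2 to compound 3 (0.17 log units; within the scatter), so these two cannot be told apart in this assay.

Compound 4, `COC(=O)CCNC1=CS(=O)(=O)O[C@@]12[C@@H](CO[Si](C)(C)C(C)(C)C)O[C@@H](n1cc(C)c(=O)n(C)c1=O)[C@@H]2O[Si](C)(C)C(C)(C)C`, has not been measured. It differs from compound 3 by methoxy in place of amino on a carbonyl carbon. Going by the values given here, this is the same kind of change as the one from compound 1 to compound 2, but the place is not the same: there the carbonyl carbon's other neighbour is an amide-type nitrogen, here it is a saturated chain carbon. Among the compounds with values here, the only guide is the earlier step of an 8.1-fold higher number from compound 1 to compound 2 (0.91 log units; beyond the scatter). Compound 3 already stands close to compound 2, so a smaller step is expected for compound 4, estimated at a 2.3-fold higher number from compound 3 to compound 4 (0.35 log units; beyond the scatter), because the same kind of change once gave an 8.1-fold higher number from compound 1 to compound 2 (0.91 log units; beyond the scatter) from a lower starting number. For compound 4 the estimate in this assay is 45000 nM, with a likely range from 15000 nM to 150000 nM.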

Compound 4, half-maximal cytotoxic concentration: > 250000 nM
Compound 4: no number, only a limit; the forecaster's own chance of this, stated with the estimate: 25%; at least 5.5-fold (0.74 log units) between middle value and limit.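

In this assay compound 4 gives > 250000 nM, which is a limit of the assay and not a number. Methoxy in place of amino on a carbonyl carbon gave an at least 12-fold higher number from compound 3 to compound 4 (1.09 log units; beyond the scatter), so the change moved the number the same way, towards lower toxicity in this test, on both cores shown: the same change on two cores in this assay, an 8.1-fold higher number (0.91 log units; beyond the scatter) from compound 1 to compound 2 and an at least 12-fold higher number (1.09 log units; beyond the scatter) from compound 3 to compound 4; the limit leaves it open whether they differ This rests on only two cores and does not show that the size of the step carries over, and the steps of an at least 8.3-fold higher number from compound 2 to compound 4 (0.92 log units; beyond the scatter) and an at least 67-fold higher number from compound 1 to compound 4 (1.82 log units; beyond the scatter) likewise give only a floor, not a true size.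

Where compound 4 really lies stays open: the limit of > 250000 nM in this assay, at which 1 of the 4 values shown sits. Also open is how a carboxylic acid in place of the methoxycarbonyl, or a longer chain on the amine nitrogen, would read in this assay, and whether the same change would push the number the same way on a third core.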